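A Sulfonyl Group Swap on Compound 3

The source may report more compounds than this note shows. Statements on the series, on what has been measured and on what is new or still open speak of the compounds shown alone.

In a functional assay on LOX IMVI cells (Homo sapiens) for cytotoxicity, read by MTT assay, with a stated time of 24 h (a higher number here means a weaker inhibitor, a lower number a stronger inhibitor), compound 1 `COc1cc(-c2nc(-c3ccccc3)[nH]c2-c2ccnc(NCCCNS(=O)(=O)c3ccc(Cl)cc3)n2)ccc1F` gives 83100 nM and compound 2 `COc1cc(-c2nc(-c3ccccc3)[nH]c2-c2ccnc(NCCCNS(=O)(=O)c3ccc(C(F)(F)F)cc3)n2)ccc1F` gives 75200 nM while compound 3 `COc1cc(-c2nc(-c3ccccc3)[nH]c2-c2ccnc(NCCCNS(=O)(=O)c3ccc(Cl)cc3)n2)ccc1Cl` gives 60900 nM and so sits level with both, within the usual scatter. Compound 4 `COc1cc(-c2nc(-c3ccccc3)[nH]c2-c2ccnc(NCCCNS(=O)(=O)c3cccc(F)c3)n2)ccc1Cl` carries 3-fluorophenyl in place of 4-chlorophenyl on a sulfonyl sulfur and is otherwise the same as compound 3. For the measured compounds named here, two measured steps bear on this swap. The closer one is a 1.1-fold lower number from compound 1 to compound 2 (0.04 log units; within the scatter) with trifluoromethyl in place of chloro on the same 4-chlorophenyl group. The other is a 1.4-fold lower number from compound 1 to compound 3 (0.13 log units; within the scatter) with chloro in place of fluoro on an aromatic carbon. Going by the values given here, both lie within the scatter, but no measured compound carries 3-fluorophenyl, so this group is untested. With only those small steps to go on, the estimated change a 1.1-fold higher number from compound 3 to compound 4 (0.06 log units; within the scatter) is expected to stay within the scatter. For compound 4 the expected value is 70000 nM with 35000 nM to 135000 nM as the estimated range.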

Compound 4, half-maximal inhibitory concentration: 5110 nM
The estimate for compound 4 lay 14-fold (1.14 log units) above the measured number; the measured number lies below the stated range.
By their numbers in this assay, from the lowest: compound 4; then compounds 3, 2 and 1 (each within the scatter of the next).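

In this assay, for the compounds shown here, the aryl group on the sulfonyl sulfur turns out to matter, with a 12-fold lower number from compound 3 to compound 4 (1.08 log units; beyond the scatter) as the only step here that lies beyond the scatter. The earlier change on this ring, trifluoromethyl in place of chloro, left the number within the scatter, so not every change at this position moves it. The two groups match in their counts of heavy atoms, donors and acceptors, and no measurement shown here explains the difference.

Because both the halogen and its place on the ring changed in one step, the compounds shown cannot say which of the two produced the drop; 3-chlorophenyl and 4-fluorophenyl would pull them apart. Also open, going by these compounds, is how an unsubstituted phenyl or a 3-aminophenyl group would behave on the same sulfur.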